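Removing the methoxy group from the piperazinyl bromopyridine

A few compounds are considered here, and "the series" means these few. Any claim that something is new, unique, unknown or untested is made for them only; others in the source may bear on it.

Measured compounds in an assay (strain Wistar) for binding affinity to Neuronal acetylcholine receptor; alpha4/beta2 (Rattus norvegicus); on this read-out higher numbers stand for weaker inhibition and lower numbers for stronger inhibition:
compound 1, `COc1cc(N2CCNCC2)cnc1Br`, 180 nM
compound 2, `COc1cncc(N2CCCNCCC2)c1`, 1 nM
compound 3, `c1cncc(N2CCCNCCC2)c1`, 0.9 nM

Compound 1 gives the highest number of the three; its nearest neighbour in value is compound 2, and compound 3 lies furthest, both of them beyond the scatter. The difference between the core of compound 1 and the core of compound 2 is not broken down here. Compound 2 and compound 3 differ in one place, (hydrogen in place of methoxy on an aromatic carbon), and the step of a 1.1-fold lower number from compound 2 to compound 3 (0.05 log units; within the scatter) is within the scatter, so the methoxy group makes no difference that can be read on this pair.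

Compound 4, `Brc1ccc(N2CCNCC2)cn1`, is not yet measured. It stands to compound 1 as compound 3 stands to compound 2: hydrogen in place of methoxy on an aromatic carbon. The two places are not identical, since in compound 1 the carbon carrying the methoxy group is ortho to a bromo group and meta to a group of 6 heavy atoms, whereas in compound 2 it is meta to a group of 8 heavy atoms; the change is therefore the same kind of change, not the same.

The expectation for compound 4 rests on compound 1, whose value is 180 nM, and on the step of a 1.1-fold lower number from compound 2 to compound 3 (0.05 log units; within the scatter), which is within the scatter. Compound 4 is therefore expected to show a step of a 1.2-fold lower number from compound 1 to compound 4 (0.08 log units; within the scatter). On that basis compound 4 is estimated at 150 nM in this assay, expected between 60 nM and 400 nM.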

Compound 4, half-maximal inhibitory concentration: 180 nM
Compound 4: middle estimate off by 1.2-fold (0.08 log units), on the low side; the range from low to high includes it.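

In this assay, hydrogen in place of methoxy on the core of compound 1 gives no change at the digits printed from compound 1 to compound 4 (within the scatter) and so agrees with the same change on the core of compound 2, the two steps lying within the scatter of each other: the same change on two cores in this assay, a 1.1-fold lower number (0.05 log units; within the scatter) from compound 2 to compound 3 and no change at the digits printed (within the scatter) from compound 1 to compound 4, 1.1-fold (0.05 log units) apart, within the scatter of two such steps

On these two cores, the change carries over with no readable effect on the number, even though the carbon concerned is ortho to a bromo group and meta to a group of 6 heavy atoms in compound 1, and has no bromo group ortho to it in compound 2. For the compounds shown here, this does not show that the methoxy group is without effect on every core, or at any other place on the ring, as the agreement rests on only two pairs and both steps are within the scatter.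

Still open, on these data alone, is whether a different group at this carbon, such as ethoxy, an amine or a carboxylic acid, would shift the number on either core. Also open, as far as these compounds go, is what the bromo group itself contributes, and whether a chloro group or a nitrile in its place would leave the number of compound 4 unchanged.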